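Aromatic substituent exchange in the methylsulfanyl-imidazoline series

The source may hold more compounds than are shown below. What is called first, only, known or untested is meant among the compounds shown, and "the series" means these compounds.

Compound 3 `CSc1ccc(Cl)cc1NCC1=NCCN1` gives 106% in a functional assay for agonist activity at Alpha-1D adrenergic receptor (Homo sapiens); on this read-out lower numbers stand for smaller maximal responses and higher numbers for larger maximal responses. Among the three measured numbers it lies within the scatter of compound 1 `CSc1ccc(C)cc1NCC1=NCCN1`, which gives 107%, while compound 2 `COc1ccc(SC)c(NCC2=NCCN2)c1`, which gives 91%, sits clearly lower. Compound 4 `CSc1ccc(C(F)(F)F)cc1NCC1=NCCN1` carries trifluoromethyl in place of chloro on an aromatic carbon. For the measured compounds named here, no measured step exchanges chloro for trifluoromethyl, so the only guidance comes from the same position: a number 1 percentage points lower from compound 1 to compound 3 (within the scatter) and a number 15 percentage points higher from compound 2 to compound 3 (beyond the scatter). These two exchanges moved this assay by at most a modest amount, and the response stayed high in every case. A step of similar or smaller size is therefore expected for compound 4, with no clear direction, estimated as a number 6 percentage points lower from compound 3 to compound 4 (within the scatter). Compound 4 is expected to give 100% in this assay, between 85% and 115%.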

Compound 4, largest response reached (reported as maximum), in percent of the reference or control that the assay uses: 58%
Estimate against measurement, compound 4: 42 percentage points above; the measured number lies below the stated range.
By their numbers in this assay, from the lowest: compound 4; then compound 2; then compounds 3 and 1 (each within the scatter of the next).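

In this assay this position is not indifferent to exchange: the response stayed high with methyl, methoxy and chloro, yet trifluoromethyl gives a number 48 percentage points lower from compound 3 to compound 4 (beyond the scatter) and a number 49 percentage points lower from compound 1 to compound 4 (beyond the scatter) and also a number 33 percentage points lower from compound 2 to compound 4 (beyond the scatter) as the steps. These are the largest steps in the set, and all three come with the entry of trifluoromethyl at this one place. Nothing on hand bears on the reason for the fall.

As far as these compounds go, whether the fall is specific to trifluoromethyl stays open. A nitrile, an amine or an ethyl chain at the same aromatic carbon would show how far it extends.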